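Flipping One Hydroxyl: From Compound 3 to Compound 4

The source may report more compounds than this note shows. Statements on the series, on what has been measured and on what is new or still open speak of the compounds shown alone.

Compound 1 `CSc1nc2cnsc2n1[C@H]1C[C@H](O)[C@@H](CO)O1` in a functional assay on KB cells (Homo sapiens) for antiproliferative activity (on this read-out higher numbers stand for weaker inhibition and lower numbers for stronger inhibition), gives > 100000 nM, which is a limit of the assay rather than a number.
Compound 2 `CSc1nc2sncc2n1[C@H]1C[C@H](O)[C@@H](CO)O1` in this assay gives 6000 nM.
Compound 3 `CSc1nc2sncc2n1[C@@H]1O[C@H](CO)[C@@H](O)[C@@H]1O` in this assay gives 15000 nM.

Among the numbers shown, compound 3 has the highest; the nearest is compound 2, and the step of a 2.5-fold higher number from compound 2 to compound 3 (0.40 log units; beyond the scatter) is modest. Compound 4 `CSc1nc2sncc2n1[C@@H]1O[C@H](CO)[C@@H](O)[C@H]1O` differs from compound 3 as follows: the two compounds have the same atoms and bonds and differ only in configuration as drawn: 1 of 4 stereo elements differ; a stereocentre at a saturated ring carbon is drawn S in compound 3 and R in compound 4. Going by the values given here, no measured step here changes configuration alone, so the step of a 2.5-fold higher number from compound 2 to compound 3 (0.40 log units; beyond the scatter) is only a loose guide to how much a small change on the sugar ring can move this assay. In this assay compound 4 is therefore expected to give 20000 nM, between 5000 nM and 80000 nM, an expected step of a 1.3-fold higher number from compound 3 to compound 4 (0.12 log units; within the scatter) within the scatter.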

Compound 4, half-maximal inhibitory concentration: 15000 nM
For compound 4 the middle estimate is 1.3-fold (0.12 log units) above the measured one; the range from low to high includes it.
By their numbers in this assay, from the lowest: compound 2; then compounds 3 and 4 (each within the scatter of the next). At a limit, above all of these: compound 1.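

Reversing the hydroxy-bearing ring carbon gives no change at the digits printed from compound 3 to compound 4 (within the scatter), so in this assay the drawn orientation of this hydroxy makes no visible difference. This comparison isolates configuration alone: the fact that compounds 3 and 4 differ only in the configuration as drawn. Replacing hydrogen with hydroxy on this carbon gives a 2.5-fold higher number from compound 2 to compound 4 (0.40 log units; beyond the scatter), matching the size of a 2.5-fold higher number from compound 2 to compound 3 (0.40 log units; beyond the scatter), so in these compounds the rise appears with the hydroxy in either orientation.

The compounds shown leave open whether an amine or a methoxy group on this carbon would behave like the hydroxy. From the compounds shown here alone, it also remains open whether the orientation would matter as little with a different group on the shared core.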